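The compounds below may be only part of what the source reports. "The series", "measured", "known", "first", "only" and "open" are said of these compounds alone.

Compound 1 `O=S(=O)(Nc1ccc(-c2nc3ccccc3o2)cc1)c1cccs1` is the only one of the three measured compounds that gives a plain number in an assay on cells for inhibition of HSP60/HSP10 (Homo sapiens), with a stated time of 60 min; a lower number here means a stronger inhibitor, a higher number a weaker inhibitor: compound 1 gives 63000 nM. Compound 2 `O=S(=O)(Nc1ccc2oc(-c3ccccc3)nc2c1)c1ccc(Cl)c(Cl)c1` reaches only the limit of > 100000 nM in this assay. Compound 3 `Cc1cccc(S(=O)(=O)Nc2ccc3oc(-c4ccccc4)nc3c2)c1` likewise reaches only the limit of > 100000 nM. The step that the two limits leave unreadable from compound 2 to compound 3 is consequently not readable. Compound 4 `O=S(=O)(Nc1ccc(-c2nc3ccccc3o2)cc1)c1ccccc1Cl` differs from compound 1 by 2-chlorophenyl in place of thiophen-2-yl on a sulfonyl sulfur. For the measured compounds named here, no measured step bears directly on this change, and the limit of > 100000 nM in this assay, at which 2 of the 3 values shown sit, leaves the one comparable step without a size. The expected step of a 1.1-fold lower number from compound 1 to compound 4 (0.02 log units; within the scatter) is therefore no larger than the usual scatter. Compound 4 is estimated at 60000 nM, with a range from 20000 nM to 150000 nM.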

Compound 4, half-maximal inhibitory concentration: > 100000 nM
Compound 4 was reported as a limit; the forecaster's own chance of this, stated with the estimate: 35%; middle value at least 1.6-fold (0.22 log units) away from the limit.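

Putting 2-chlorophenyl in place of thiophen-2-yl on the sulfonyl sulfur gives, in this assay, an at least 1.5-fold higher number from compound 1 to compound 4 (0.20 log units; that floor lies within the scatter). For the compounds shown here, this is the first step with any readable size, but it is only a floor, so the change may be slight or much larger. Its true size stays hidden because the read-out stops at a limit: the limit of > 100000 nM in this assay, at which 3 of the 4 values shown sit.

Going by these compounds, whether the chlorine or the six-membered ring matters more remains open, and a plain phenyl group at this place would help separate the two. On these data alone, what an amine or a carboxylic acid on that ring would do also remains open.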